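The source may report more compounds than this note shows. Statements on the series, on what has been measured and on what is new or still open speak of the compounds shown alone.

Series so far in an ADME assay for permeability, using PAMPA, with a stated time of 4 h; on this read-out higher numbers stand for higher permeability and lower numbers for lower permeability:
- compound 1 `Cc1c(F)ccc(C(=O)Nc2cc(C(=O)Oc3ccccc3)ccc2N2CCN(C)CC2)c1Cl` gives 48 10^-6 cm/s
- compound 2 `Cc1c(F)c([N+](=O)[O-])cc(C(=O)Nc2cc(C(=O)Oc3ccccc3)ccc2N2CCN(C)CC2)c1Cl` gives 56.3 10^-6 cm/s
- compound 3 `Cc1c(F)ccc(C(=O)Nc2cc(C(=O)OC(C)C)ccc2N2CCN(C)CC2)c1Cl` has no measurement yet

Among the measured compounds shown here, only two numbers exist, and compound 1 lies within the scatter of compound 2, so no order can be read between them. For the measured compounds named here, the one measured step is a 1.2-fold higher number from compound 1 to compound 2 (0.07 log units; within the scatter), with nitro in place of hydrogen on an aromatic carbon.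

Compound 3 differs from compound 1 at another place: isopropyl in place of phenyl on an oxygen next to a carbonyl group. In words, this is isopropyl in place of phenyl on an oxygen next to a carbonyl group. Going by the values given here, no measured compound carries a change at this place, so the data give no direct guide to its size or direction. Among the compounds with values here, the nitro step bears on it only weakly, as the single measured change, and it stayed within the scatter.

In this assay no step beyond the scatter is therefore expected, and no direction is favoured. The estimated step is a 1.1-fold lower number from compound 1 to compound 3 (0.03 log units; within the scatter). For compound 3 the expected value is 45 10^-6 cm/s, with an estimated range of 18 10^-6 cm/s to 95 10^-6 cm/s.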

Compound 3, apparent permeability: 49.8 10^-6 cm/s
The estimate for compound 3 lay 1.1-fold (0.04 log units) below the measured number, and the stated range covers the measured number.
By their numbers in this assay, from the lowest: compounds 1, 3 and 2 (each within the scatter of the next).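

Among the compounds shown here, at the oxygen next to a carbonyl group, the first measured change in this assay is isopropyl in place of phenyl, and it gives a 1.0-fold higher number from compound 1 to compound 3 (0.02 log units; within the scatter). This position therefore accepts a swap from phenyl, with 6 heavy atoms and a six-membered aromatic ring, to isopropyl, with 3 heavy atoms and no ring, without any step beyond the scatter on this read-out; the aromatic ring is not required here to keep the number of compound 1 within reach, at least for this one pair. For the compounds shown here, nothing measured so far offers an explanation for the absence of a step at this place.

Going by these compounds, it remains open whether a different kind of group at the same place, such as a longer chain, a chain ending in an amine, or a carboxylic acid in place of the whole phenoxycarbonyl, would give a step beyond the scatter. Also open, on these data alone, is whether isopropoxycarbonyl and the nitro group, carried together on the core of compound 1, would stay within the scatter of compound 1.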